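The source may report more compounds than this note shows. Statements on the series, on what has been measured and on what is new or still open speak of the compounds shown alone.

Measured compounds:
Compound 1, `CC(C)(C)n1ncc(OCc2nnc(-c3ccc(Cl)cc3)s2)c(Cl)c1=O`, gives 106000 nM in a functional assay on the whole organism for inhibition, with Mythimna separata as the target, with a stated time of 5 days; a higher number here means that more compound is needed for the effect, a lower number that less compound is needed.
Compound 2, `CC(C)(C)n1ncc(OCc2nnc(-c3ccco3)o2)c(Cl)c1=O`, gives only a limit of the assay in this assay, namely > 299000 nM.

Among the measured compounds shown here, compound 1 thus holds the only numerical value in this assay; the other entry, for compound 2, is a limit and not a number, and (the limit of > 299000 nM in this assay, at which 1 of the 2 values shown sits). Compound 3, `CC(C)(C)n1ncc(OCc2nnc(-c3ccc(F)cc3)s2)c(Cl)c1=O`, differs from compound 1 in a single place: fluoro in place of chloro on an aromatic carbon, on an aromatic carbon of a six-membered aromatic ring of carbon only, para to a large group, so that a 4-chlorophenyl becomes a 4-fluorophenyl. For the measured compounds named here, no step between two measured compounds is available, so the size of this change cannot be read off from the data and can only be expected. The step from compound 1 to compound 3 is expected to be a 1.9-fold higher number from compound 1 to compound 3 (0.28 log units; within the scatter), a modest loss of potency that may reach just beyond the usual scatter, with a real chance that the assay again reports only a limit. Compound 3 is therefore estimated at 200000 nM, within a range from 80000 nM to 500000 nM.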

Compound 3, half-maximal effective concentration: 21500 nM
Compound 3: middle estimate off by 9.3-fold (0.97 log units), on the high side; measured number outside the range, below it.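

In this assay, replacing chloro with fluoro on the six-membered aromatic ring, para to a large group, gives a 4.9-fold lower number from compound 1 to compound 3 (0.69 log units; beyond the scatter). Among the compounds shown here, this is the first step that can be read, and it shows that this position responds to a change of a single halogen, which the earlier compounds could not show. The response here is a gain in potency, with the 4-fluorophenyl compound 3 needing less compound for the effect than the 4-chlorophenyl compound 1, but no measured property shown accounts for the difference, so the step stands as an observation without an explanation.

From the compounds shown here alone, only these two halogens are compared at this position, so it remains open how a bromo, a methoxy, a nitrile or a plain hydrogen there would behave, and whether the gain would carry over to other parts of the shared core. For the compounds shown here, compound 2 gives only a limit of the assay and differs from compound 1 and compound 3 in more than one place, so no step to it can be read.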